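The source may report more compounds than this note shows. Statements on the series, on what has been measured and on what is new or still open speak of the compounds shown alone.

In a functional assay on HUVEC cells (Homo sapiens) for inhibition, read by crystal violet staining, with a stated time of 72 h (on this read-out lower numbers stand for stronger inhibition of growth and higher numbers for weaker inhibition of growth), compound 1 (`COc1ccc(-n2nccc2-c2cc(OC)c(OC)c(OC)c2)cc1O`) reports > 750 nM as a limit of the test and not as a number. Within the data shown here, compound 2 (`COc1ccc(-c2cnn(C)c2-c2cc(OC)c(OC)c(OC)c2)cc1O`) gives 68 nM in this assay and so holds the only true number so far, which leaves nothing measured to rank it against. The next compound to be read is compound 3 (`COc1ccc(-c2cn[nH]c2-c2cc(OC)c(OC)c(OC)c2)cc1O`). It departs from compound 2 at one place (hydrogen in place of methyl on an aromatic nitrogen), with hydrogen in place of methyl on an aromatic nitrogen, next to the ring nitrogen and next to the ring atom that bears a large group. Among the measured compounds shown here, no measured pair of compounds shows this exchange, so what follows is a judgement and not a reading. Taking compound 2 at 68 nM as the starting point, a modest loss of growth inhibition is expected in this assay and the result should still be a true number. The estimated step is a 1.9-fold higher number from compound 2 to compound 3 (0.28 log units; within the scatter) and would move toward weaker inhibition. Compound 3 is expected at 130 nM within a range from 30 nM to 600 nM when it is measured.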

Compound 3, concentration for 50% growth inhibition: > 5000 nM
Compound 3 gave a limit, no number; the forecaster's own chance of this, stated with the estimate: 12%; at least 38-fold (1.58 log units) between middle value and limit.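

In this assay, the methyl on the aromatic nitrogen proves to matter far more than the loss of a single carbon atom might suggest: putting hydrogen in its place gives an at least 73-fold higher number from compound 2 to compound 3 (1.86 log units; beyond the scatter). Among these compounds, until now compound 2 held the only true number, with nothing to set it against, so this pair is the first to show that growth inhibition responds strongly to what sits on that nitrogen. The printed step marks only the smallest size the change can have and not its exact size, as the reading for compound 3 is a limit of the test and not a number: the limit of > 5000 nM in this assay, at which 1 of the 3 values shown sits.

The compounds shown leave open whether any group other than methyl on this nitrogen keeps the growth inhibition, for example an ethyl group, a longer chain or a chain ending in an amine. They also leave open whether the same exchange would have a similarly large effect on a compound carrying another group in place of the 3-hydroxy-4-methoxyphenyl group.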